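This account rests on a few compounds, and the source may have more. Where it says the series, first, only, none or still open, it means among the compounds named here.

Measured so far:
compound 1, `Cc1nc(NC(=O)NCc2ccccc2)c2nn(-c3ccccc3)cc2n1`, 26%
compound 2, `Cc1nc(NC(=O)c2ccccc2)c2nn(-c3ccccc3)cc2n1`, 30%
compound 3, `O=C(Nc1nc(-c2ccccc2)nc2cn(-c3ccccc3)nc12)c1ccco1`, 11%

These three compounds were tested in an assay on CHO cells for displacement of a labelled ligand from adenosine receptor A1 (Homo sapiens), read by scintillation counting, with a stated time of 120 min, tested at 1 uM; a higher number here means more inhibition at the concentration tested (going by the name of the read-out), a lower number less inhibition. Compound 2 has the highest of the three numbers; its nearest neighbour is compound 1, and the furthest is compound 3, whose value lies beyond the scatter below that of compound 2. For the measured compounds named here, no step is described between compound 2 and compound 3, so their two values are all that can be said of that pair.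

Compound 4, `CC(=O)Nc1nc(C)nc2cn(-c3ccccc3)nc12`, is not yet measured. It differs from compound 2 by methyl in place of phenyl on a carbonyl carbon.

Going by the values given here, only one measured step touches the same place on the shared core, the carbonyl carbon: a number 4 percentage points higher from compound 1 to compound 2 (within the scatter). That step, benzylamino to phenyl, stayed within the scatter, which suggests that what hangs on this carbonyl carbon has not moved the number much among the compounds seen. The change to compound 4 also trades one group for another at this position, so no step beyond the scatter is expected in this assay, although the smaller methyl group gives little to hold on to, and a modest drop would not surprise.

Compound 4 is therefore estimated at 22%, with a range from 5% to 40%, an expected step of a number 8 percentage points lower from compound 2 to compound 4 (within the scatter).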

Compound 4, a percentage reported as inhibition, at one concentration (the size of the read-out at that concentration, not a potency): 25%
Compound 4: middle estimate off by 3 percentage points, on the low side; low and high end bracket the measured number.
By their numbers in this assay, from the lowest: compound 3; then compounds 4, 1 and 2 (each within the scatter of the next).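

In this assay, methyl in place of phenyl on the carbonyl carbon gives a number 5 percentage points lower from compound 2 to compound 4 (within the scatter) and so leaves the number within the usual spread, even though a six-carbon aromatic ring gives way to a single carbon. Methyl in place of benzylamino at the same carbon gives a number 1 percentage points lower from compound 1 to compound 4 (within the scatter) and likewise stays within the scatter, so compounds 1, 2 and 4 cannot be told apart here, and a ring on this carbonyl carbon is not required for a number at this level. No measurement at hand explains why these three groups give such similar numbers.

Going by these compounds, whether other groups on this carbonyl carbon, such as a longer chain like butyl, an amine like dimethylamino or a carboxylic acid, would leave the number just as level remains open. Compound 3 differs from the others in more than one place, so the compounds shown cannot say which of its changes goes with its lower number, nor whether its furan ring on the carbonyl carbon plays any part.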